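Swapping thiophene for furan on the weakest of three anilinopyrimidines

The compounds below may be only part of what the source reports. "The series", "measured", "known", "first", "only" and "open" are said of these compounds alone.

Three compounds share an anilino-pyrimidine core and differ only in the aromatic group attached to it. Compound 1 `Cc1cc(C)cc(Nc2nccc(-c3ccccn3)n2)c1` gives 100 nM in a functional assay for inhibition, with Homo sapiens as the target; on this read-out lower numbers stand for stronger inhibition and higher numbers for weaker inhibition. Compound 2 `Cc1cc(C)cc(Nc2nccc(-c3cccnc3)n2)c1` gives 800 nM, a change of an 8.0-fold higher number from compound 1 to compound 2 (0.90 log units; beyond the scatter). Compound 3 `Cc1cc(C)cc(Nc2nccc(-c3cccs3)n2)c1` gives 4300 nM, the highest of the three numbers; the steps of a 43-fold higher number from compound 1 to compound 3 (1.63 log units; beyond the scatter) and a 5.4-fold higher number from compound 2 to compound 3 (0.73 log units; beyond the scatter) both set it apart from the other two beyond the scatter.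

Compound 4 `Cc1cc(C)cc(Nc2nccc(-c3ccco3)n2)c1` is the next, unmeasured, compound: furan-2-yl in place of thiophen-2-yl on an aromatic carbon. Going by the values given here, no measured step exchanges a five-membered ring for another, so none bears directly on this change; the steps from compound 1 and compound 2 to compound 3 only show that the five-membered thiophene sits well behind both pyridines. With nothing to separate furan-2-yl from thiophen-2-yl in these data, compound 4 is expected to stay close to compound 3, a step of a 1.2-fold lower number from compound 3 to compound 4 (0.09 log units; within the scatter) that lies within the scatter. Compound 4 is therefore estimated at 3500 nM, with a range from 1200 nM to 12000 nM.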

Compound 4, half-maximal inhibitory concentration: 700 nM
Compound 4: the middle estimate sits 5.0-fold (0.70 log units) above what was measured; measured number below the stated range.
By their numbers in this assay, from the lowest: compound 1; then compounds 4 and 2 (each within the scatter of the next); then compound 3.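

At this position the two five-membered rings are not interchangeable: they match in heavy-atom count and each carries one hetero atom, yet oxygen in place of sulfur gives a 6.1-fold lower number from compound 3 to compound 4 (0.79 log units; beyond the scatter) in this assay. The lag of compound 3 behind the pyridines therefore belongs to thiophen-2-yl and not to five-membered rings as a class, since furan-2-yl shows a 1.1-fold lower number from compound 2 to compound 4 (0.06 log units; within the scatter), which leaves the two compounds level within the scatter. Pyridin-2-yl keeps its lead over the furan, with a 7.0-fold higher number from compound 1 to compound 4 (0.85 log units; beyond the scatter).

Nothing shown explains why oxygen and sulfur part so clearly here. The compounds shown leave open how a phenyl ring, an oxazol-2-yl ring or a simple amine would fare on this aromatic carbon.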